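A few compounds are considered here, and "the series" means these few. Any claim that something is new, unique, unknown or untested is made for them only; others in the source may bear on it.

Measured compounds in an assay for inhibition of Thromboxane-A synthase (Homo sapiens), using microsomes; on this read-out lower numbers stand for stronger inhibition and higher numbers for weaker inhibition:
compound 1 `N#Cc1ccccc1C1OCC(C/C=C\CCC(=O)O)C(c2cccnc2)O1` — 54 nM
compound 2 `O=C(O)CC/C=C\CC1COC(c2ccc([N+](=O)[O-])cc2)OC1c1cccnc1` — 39 nM
compound 3 `CSc1ccc(OC(C)(C)C2OCC(C/C=C\CCC(=O)O)C(c3cccnc3)O2)c([N+](=O)[O-])c1` — 22 nM

On these three numbers compound 3 stands lowest, though its gap to compound 2 lies within the scatter; only its gap to compound 1 lies beyond it. Compound 4 `Cc1ccc(OC(C)(C)C2OCC(C/C=C\CCC(=O)O)C(c3cccnc3)O2)cc1` differs from compound 3 at one place: a group of 7 heavy atoms (7 carbon; one six-membered aromatic ring of carbon only) in place of a group of 11 heavy atoms (7 carbon, 1 nitrogen, 2 oxygen, 1 sulfur; one six-membered aromatic ring of carbon only), on an oxygen on a saturated carbon. Within the data shown here, the only measured step is a 1.4-fold lower number from compound 1 to compound 2 (0.14 log units; within the scatter), a change of the aryl group on a saturated ring carbon, not on the oxygen where compound 4 differs; it stayed within the scatter and gives no direct guide to this change. Among the measured compounds compound 3 is the only one carrying a group on that oxygen, so the data give no step for removing the nitrogen, oxygen and sulfur of the leaving group. With nothing pointing either way, no step beyond the scatter is expected: a 1.8-fold higher number from compound 3 to compound 4 (0.26 log units; within the scatter), with a wide range to reflect the absence of a matching precedent. Compound 4 is therefore estimated at 40 nM in this assay, between 12 nM and 130 nM.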

Compound 4, half-maximal inhibitory concentration: 360 nM
The estimate for compound 4 lay 9.0-fold (0.95 log units) below the measured number; measured number above the stated range.
By their numbers in this assay, from the lowest: compounds 3, 2 and 1 (each within the scatter of the next, the first and the last beyond it); then compound 4.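

In this assay, among these compounds, the group on an oxygen on a saturated carbon turns out to matter: 4-methylphenyl in place of the group of 11 heavy atoms gives a 16-fold higher number from compound 3 to compound 4 (1.21 log units; beyond the scatter), so this place responds far more strongly than the earlier compounds could show. Among the compounds shown here, the only earlier step, a 1.4-fold lower number from compound 1 to compound 2 (0.14 log units; within the scatter), concerned an aryl group on a saturated ring carbon and gave no sign of a change of this size, so the two places cannot be treated alike. The change removes the nitrogen, the sulfur, the two oxygens and all 3 hydrogen-bond acceptors of the leaving group at once, and nothing measured here gives a reason for the step.

For the compounds shown here, the single step does not separate these features, so it remains open which part of the leaving group accounts for the difference between the two compounds. Also open, as far as these compounds go, is how the number would respond to a different group on the aromatic ring of 4-methylphenyl, such as an amine, a chlorine atom or a carboxylic acid, in place of the methyl group.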